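The source may hold more compounds than are shown below. What is called first, only, known or untested is meant among the compounds shown, and "the series" means these compounds.

Working notes on the series. Compound 1, `C=CC(=O)Nc1cc(CCO)cc(C)c1Nc1ncc2cc(-c3c(Cl)c(OC)cc(OC)c3Cl)ccc2n1`, gives 2410 nM in a functional assay on Huh-7 cells (Homo sapiens) for inhibition, read by sulforhodamine B assay, with a stated time of 72 h; a higher number here means a weaker inhibitor, a lower number a stronger inhibitor. Compound 2, `C=CC(=O)Nc1cc(S(C)(=O)=O)cc(C)c1Nc1ncc2cc(-c3c(Cl)c(OC)cc(OC)c3Cl)ccc2n1`, gives 1940 nM in the same assay. Among the measured compounds shown here, the only step between measured compounds, a 1.2-fold lower number from compound 1 to compound 2 (0.09 log units; within the scatter), exchanges the 2-hydroxyethyl on the aromatic carbon for methylsulfonyl, and it stays within the scatter. For the measured compounds named here, on the two numbers known, compound 2 carries the lower one, with compound 1 within the scatter of it, so neither can be called the stronger inhibitor.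

Compound 3, `C=CC(=O)Nc1cc(S(N)(=O)=O)cc(C)c1Nc1ncc2cc(-c3c(Cl)c(OC)cc(OC)c3Cl)ccc2n1`, is the next member and awaits measurement. It differs from compound 2 by amino in place of methyl on a sulfonyl sulfur, that is, methylsulfonyl becomes sulfamoyl. Going by the values given here, no measured step touches the sulfonyl sulfur itself; the one step known concerns the group attached to the aromatic carbon, and it was within the scatter. Among the compounds with values here, there is therefore no precedent for a shift in this assay beyond the scatter, in either direction. The step from compound 2 to compound 3 is estimated as a 1.0-fold higher number from compound 2 to compound 3 (0.01 log units; within the scatter). Compound 3 is expected to give about 2000 nM, with a range from 800 nM to 5000 nM.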

Compound 3, half-maximal inhibitory concentration: 1670 nM
Beside the measured number, compound 3's estimate is 1.2-fold (0.08 log units) above it, within the range that was stated.
By their numbers in this assay, from the lowest: compounds 3, 2 and 1 (each within the scatter of the next).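

On the sulfonyl sulfur, the exchange of methyl, with 0 hydrogen-bond donors, for amino, with 1 hydrogen-bond donor, gives in this assay a 1.2-fold lower number from compound 2 to compound 3 (0.07 log units; within the scatter), so this first change at the sulfur itself leaves the number within the scatter. Among the compounds shown here, the exchange of 2-hydroxyethyl for sulfamoyl on the aromatic carbon, a 1.4-fold lower number from compound 1 to compound 3 (0.16 log units; within the scatter), also stays within the scatter, so all three groups now tested at that carbon give numbers that cannot be told apart, and no compound of the three can be called the stronger inhibitor. No measurement is at hand that bears on why these numbers stay together.

The compounds shown leave open whether any group on that aromatic carbon can shift the number beyond the scatter, for example an amine, a carboxylic acid or a longer chain ending in a morpholine. They also leave open whether a larger substituent on the sulfonyl sulfur, such as dimethylamino or a piperazine, would still stay within the scatter of compound 2 in this assay.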